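A few compounds are considered here, and "the series" means these few. Any claim that something is new, unique, unknown or untested is made for them only; others in the source may bear on it.

Measured so far:
- Compound 1 `CCCOc1c(Br)cc(/C=C2\CCC/C(=C\c3ccccc3[N+](=O)[O-])C2=O)cc1OC`: 1.99 ug/mL
- Compound 2 `COc1cccc(/C=C2\CCC/C(=C\c3cccc([N+](=O)[O-])c3)C2=O)c1`: 13.2 ug/mL

Both were tested in a functional assay on MDA-MB-231 cells (Homo sapiens) for cytotoxicity, read by MTT assay; a lower number here means a stronger inhibitor, a higher number a weaker inhibitor. Compound 1 gives 1.99 ug/mL in this assay, the lowest of the two numbers; compound 2 gives 13.2 ug/mL, a gap beyond the scatter. Going by the values given here, the two differ in more than one place, so no single step links them, and their values can only be set side by side.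

Compound 3 `CCCOc1c(Br)cc(/C=C2\CCC/C(=C\c3cccc([N+](=O)[O-])c3)C2=O)cc1OC` has not yet been measured. It differs from compound 1 in one place: 3-nitrophenyl in place of 2-nitrophenyl on a double-bonded chain carbon bound to a double-bonded ring carbon. Compound 2 also carries a 3-nitrophenyl group and shows a higher number than compound 1, but compound 2 differs from compound 1 elsewhere too, so it offers only a loose hint. On that basis a modest step toward a higher number is expected, one that may still fall within the scatter. Compound 3 is estimated at 4 ug/mL, with a range of 1.5 ug/mL to 12 ug/mL. The expected step is a 2.0-fold higher number from compound 1 to compound 3 (0.30 log units; within the scatter).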

Compound 3, half-maximal inhibitory concentration: 2.99 ug/mL
Compound 3: middle estimate off by 1.3-fold (0.13 log units), on the high side; low and high end bracket the measured number.
By their numbers in this assay, from the lowest: compounds 1 and 3 (each within the scatter of the next); then compound 2.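

In this assay, going by these compounds alone, 3-nitrophenyl in place of 2-nitrophenyl on a double-bonded chain carbon bound to a double-bonded ring carbon gives a 1.5-fold higher number from compound 1 to compound 3 (0.18 log units; within the scatter), the first direct reading of a change at this position. On the core of compound 1, the assay therefore does not separate these two nitrophenyl groups, which have the same atoms joined differently. Within the data shown here, this result rests on a single pair, so it describes only this change on this core and sets no wider rule for the position. No measured evidence is available to explain why the two groups read alike.

The compounds shown leave open how far this position tolerates larger changes, such as an aminophenyl group or a carboxyphenyl group in place of the nitrophenyl group, and whether either would give a number beyond the scatter. From the compounds shown here alone, it also remains open whether 3-nitrophenyl and 2-nitrophenyl would still read alike on a different core, for example one carrying a longer chain in place of the propyl chain of compound 1.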